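Cytotoxicity notes on a benzyl-thio pyrimidinone pair and one analogue

The source may hold more compounds than are shown below. What is called first, only, known or untested is meant among the compounds shown, and "the series" means these compounds.

Compound 1 `Cc1cc(C)cc(Cc2nc(SCc3ccc([N+](=O)[O-])cc3)[nH]c(=O)c2I)c1`: 39000 nM
Compound 2 `Cc1cc(C)cc(Cc2nc(SCCOc3ccccc3)[nH]c(=O)c2I)c1`: > 100000 nM

In an ADME assay on HepG2 2.2.15 cells (Homo sapiens) for cytotoxicity, read by MTT assay, with a stated time of 72 h (a lower number here means that less compound is tolerated, a higher number that more compound is tolerated), compound 1 gives 39000 nM. For compound 2 this assay reports only a limit, > 100000 nM. Going by the values given here, compound 1 thus holds the only actual number in the set; the other entry is a limit. Among the compounds with values here, the one measured step, an at least 2.5-fold higher number from compound 1 to compound 2 (0.40 log units; beyond the scatter), exchanges the whole group on the sulfur-bound chain carbon and runs into (the limit of > 100000 nM in this assay, at which 1 of the 2 values shown sits), so its true size is not known.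

Compound 3 `COC(=O)c1ccc(CSc2nc(Cc3cc(C)cc(C)c3)c(I)c(=O)[nH]2)cc1` differs from compound 1 by methoxycarbonyl in place of nitro on an aromatic carbon. Within the data shown here, no measured step touches this aromatic substituent, so the measured step gives only a loose guide; a change of no more than modest size, if any beyond the scatter, is expected. Compound 3 is therefore estimated at 50000 nM, with a range of 20000 nM to 120000 nM. The estimated step is a 1.3-fold higher number from compound 1 to compound 3 (0.11 log units; within the scatter).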

Compound 3, half-maximal cytotoxic concentration: 64800 nM
For compound 3 the middle estimate is 1.3-fold (0.11 log units) below the measured one, within the range that was stated.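

Going by these compounds alone, compound 3 gives the series a second actual number, so a change on the aromatic ring can now be read directly in this assay, whereas the only earlier step exchanged the whole group on the chain carbon and ended at a limit. Methoxycarbonyl in place of nitro gives a 1.7-fold higher number from compound 1 to compound 3 (0.22 log units; within the scatter), so the two groups cannot be told apart at this aromatic carbon, para to a large group. Within this pair, the exchange of one of these groups for the other leaves cytotoxicity unresolved, and that reading covers these two groups only.

Going by these compounds, whether an amine or a carboxylic acid on this aromatic carbon would shift the number beyond the scatter remains open. The size of the change on the chain carbon also remains unknown, because compound 2 reports only a limit: the limit of > 100000 nM in this assay, at which 1 of the 3 values shown sits.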